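Swapping a Sulfone Linker for a Sulfonamide

This account rests on a few compounds, and the source may have more. Where it says the series, first, only, none or still open, it means among the compounds named here.

Of the compounds shown here, three built on one shared core have been measured in a functional assay on K562 cells (Homo sapiens) for inhibition, read by trypan blue exclusion, with a stated time of 72 h; on this read-out higher numbers stand for weaker inhibition and lower numbers for stronger inhibition. Compound 1 `COc1ccc(Nc2ncc3cc(S(=O)(=O)c4ccc(C)cc4)c(=O)n(C)c3n2)cc1` gives 75000 nM, while compound 3 `Cn1c(=O)c(S(=O)(=O)c2ccc(F)cc2F)cc2cnc(Nc3ccccn3)nc21` gives 35000 nM. Compound 2 `Cn1c(=O)c(S(=O)(=O)Cc2ccc(F)cc2F)cc2cnc(Nc3ccc4[nH]ccc4c3)nc21` gives 1000 nM, the lowest of the three numbers, and its gaps to compound 3 and to compound 1 both lie beyond the usual scatter. Compound 4 `Cn1c(=O)c(S(=O)(=O)Nc2ccc(F)cc2F)cc2cnc(Nc3ccc4[nH]ccc4c3)nc21` has not yet been measured. It differs from compound 2 in one place: (2,4-difluorophenyl)amino in place of 2,4-difluorobenzyl on a sulfonyl sulfur. Among the measured compounds shown here, no two measured compounds differ in a single place, so this kind of change has no tested precedent here. A small step, within the scatter or leaning toward weaker inhibition, is expected, a 2.0-fold higher number from compound 2 to compound 4 (0.30 log units; within the scatter). Compound 4 is therefore estimated at 2000 nM, with a range from 500 nM to 10000 nM.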

Compound 4, half-maximal inhibitory concentration: 5000 nM
For compound 4 the middle estimate is 2.5-fold (0.40 log units) below the measured one; the range from low to high includes it.
By their numbers in this assay, from the lowest: compound 2; then compound 4; then compound 3; then compound 1.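

In this assay, among the compounds shown here, (2,4-difluorophenyl)amino in place of 2,4-difluorobenzyl on a sulfonyl sulfur gives a 5.0-fold higher number from compound 2 to compound 4 (0.70 log units; beyond the scatter), the first comparison here that changes a single place. The two groups have the same count of heavy atoms and the same aromatic ring, and the entering group adds a hydrogen-bond donor, so even this close swap moves the number beyond the scatter. No measurement here explains the shift. Going by these compounds, how an unsubstituted amine on the sulfonyl sulfur, or a longer chain carrying the difluorophenyl ring, would compare remains open.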